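Oxygen-to-sulfur linker swap on the aryl ether series

This account rests on a few compounds, and the source may have more. Where it says the series, first, only, none or still open, it means among the compounds named here.

Compound 3 `Nc1cc(N)c2nc(-c3ccccc3)c(Oc3ccc(F)cc3)nc2c1` gives 3890 nM in a functional assay on MDA-MB-231 cells (Homo sapiens) for inhibition, read by sulforhodamine B assay, with a stated time of 48 h (a higher number here means a weaker inhibitor of growth, a lower number a stronger inhibitor of growth), the lowest of the two numbers available; compound 1 `Nc1cc(N)c2nc(-c3ccccc3)c(Oc3ccc(Cl)c(Cl)c3)nc2c1` gives 10200 nM, and the step of a 2.6-fold lower number from compound 1 to compound 3 (0.42 log units; beyond the scatter) separates them. Compound 2 `COc1ccc(Sc2nc3cc(N)cc(N)c3nc2-c2ccccc2)cc1` gives only a limit, < 100000 nM in this assay (the limit of < 100000 nM in this assay, at which 1 of the 3 values shown sits). Compound 4 `Nc1cc(N)c2nc(-c3ccccc3)c(Sc3ccc(F)cc3)nc2c1` differs from compound 3 by (4-fluorophenyl)sulfanyl in place of 4-fluorophenoxy on an aromatic carbon. The steps a step that the limit leaves unreadable from compound 1 to compound 2 and a step that the limit leaves unreadable from compound 2 to compound 3 both include an oxygen-to-sulfur exchange. Within the data shown here, each of these two steps is unreadable, and each also changes the aryl group, so no measured step isolates this change. Compound 4 is therefore expected to sit near compound 3, with a 1.2-fold higher number from compound 3 to compound 4 (0.06 log units; within the scatter) in this assay not beyond the scatter; the estimate for compound 4 is 4500 nM, within 1500 nM to 15000 nM.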

Compound 4, concentration for 50% growth inhibition: 17400 nM
For compound 4 the middle estimate is 3.9-fold (0.59 log units) below the measured one; measured number above the stated range.
By their numbers in this assay, from the lowest: compound 3; then compounds 1 and 4 (each within the scatter of the next).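

At the aromatic carbon next to the ring nitrogen, with the 4-fluorophenyl group held fixed, the oxygen-to-sulfur exchange now has a readable size in this assay: a 4.5-fold higher number from compound 3 to compound 4 (0.65 log units; beyond the scatter). Against the 3,4-dichlorophenoxy compound, the sulfur compound shows a 1.7-fold higher number from compound 1 to compound 4 (0.23 log units; within the scatter), so those two stay level. The step from compound 2 cannot be read, as compound 2 gives only a limit: the limit of < 100000 nM in this assay, at which 1 of the 4 values shown sits.

Open, as far as these compounds go, is whether an amine or sulfonyl linker at this position keeps the activity of the ether, and whether the exchange gives a like step with 3,4-dichlorophenyl. No measured property on hand accounts for the step.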